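Adding a carbamoyl arm to the thioether of compound 2

The source may hold more compounds than are shown below. What is called first, only, known or untested is meant among the compounds shown, and "the series" means these compounds.

Measured compounds:
- compound 1, `CCCCCCSc1ccn([C@@H]2O[C@H](COP(=O)(O)OP(=O)(O)O)[C@@H](O)[C@H]2O)c(=O)n1`: 4900 nM
- compound 2, `CSc1ccn([C@@H]2O[C@H](COP(=O)(O)OP(=O)(O)O)[C@@H](O)[C@H]2O)c(=O)n1`: 2300 nM

In an in vitro functional assay on 1321-N1 cells for agonist activity at P2Y purinoceptor 6 (Homo sapiens) (a higher number here means that more compound is needed for the effect, a lower number that less compound is needed), compound 1 gives 4900 nM, and compound 2 gives 2300 nM. Compound 2 stands lowest of the two numbers; its nearest neighbour is compound 1, the difference being a 2.1-fold lower number from compound 1 to compound 2 (0.33 log units; beyond the scatter), a modest step tied to hydrogen in place of pentyl on a saturated chain carbon bound to a sulfur.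

Compound 3, `NC(=O)CSc1ccn([C@@H]2O[C@H](COP(=O)(O)OP(=O)(O)O)[C@@H](O)[C@H]2O)c(=O)n1`, has not yet been measured. It differs from compound 2 by carbamoyl in place of hydrogen on a saturated chain carbon bound to a sulfur. Among the measured compounds shown here, the only measured step that touches this carbon, a 2.1-fold lower number from compound 1 to compound 2 (0.33 log units; beyond the scatter), shows that changing what hangs from it moves the number only modestly. Because that step a 2.1-fold lower number from compound 1 to compound 2 (0.33 log units; beyond the scatter) was small, a small step is expected here too, with no clear direction. Compound 3 is therefore expected to give about 2000 nM, with a plausible range from 600 nM to 6500 nM, meaning an expected step of a 1.2-fold lower number from compound 2 to compound 3 (0.06 log units; within the scatter).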

Compound 3, half-maximal effective concentration: 18000 nM
Compound 3: the middle estimate sits 9.0-fold (0.95 log units) below what was measured; the measured number lies above the stated range.
By their numbers in this assay, from the lowest: compound 2; then compound 1; then compound 3.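

In this assay, what hangs from this saturated chain carbon bound to a sulfur can move the number further than the first step suggested: adding carbamoyl gives a 7.8-fold higher number from compound 2 to compound 3 (0.89 log units; beyond the scatter), and replacing pentyl with carbamoyl gives a 3.7-fold higher number from compound 1 to compound 3 (0.57 log units; beyond the scatter). The short carbamoyl arm ends up higher than the longer pentyl-bearing chain, so among these three compounds, chain length alone does not set the order. No available evidence explains why the carbamoyl arm raises the number.

As far as these compounds go, it remains open which part of the carbamoyl group goes with the rise, and a carboxylic acid, a methyl ester or an amine on the same carbon could help separate them. An ethyl or propyl chain would show how the number changes between methyl and pentyl.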